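The compounds below may be only part of what the source reports. "The series", "measured", "known", "first", "only" and "open" are said of these compounds alone.

Compound 1 `COc1ccc(/C=C/C(=O)O)cc1OC(=O)c1nc(C)c(C)nc1C` was tested in a functional assay on EA.hy 926 cells (Homo sapiens) for cytotoxicity, read by MTT assay, with stated times of 24 h and 12 h, tested at 12.5 uM (on this read-out lower numbers stand for a weaker effect and higher numbers for a stronger effect at the one concentration tested), and gives 41.3%. Compound 3 `Cc1nc(C)c(C(=O)Oc2cccc(/C=C/C(=O)O)c2)nc1C` gives 61.6% in this assay. The two differ in a single place: hydrogen in place of methoxy on an aromatic carbon. That change made a number 20.3 percentage points higher from compound 1 to compound 3 (beyond the scatter). Compound 2 `CCOC(=O)/C=C/c1cc(OC)c(OC(=O)c2nc(C)c(C)nc2C)c(OC)c1` gives 96.6% in this assay, the highest of the three numbers, and the difference between its core and the core of compound 1 is not broken down here.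

Compound 4 `CCOC(=O)/C=C/c1ccc(OC(=O)c2nc(C)c(C)nc2C)c(OC)c1` has not yet been measured in this assay. It differs from compound 2 by hydrogen in place of methoxy on an aromatic carbon. Among the compounds with values here, this is the same kind of change as the one from compound 1 to compound 3, though the surroundings differ: in compound 1 the carbon that loses the methoxy is ortho to a large group and para to a 2-carboxyethenyl group, whereas in compound 2 it is ortho to a large group, meta to a 2-(ethoxycarbonyl)ethenyl group and meta to a methoxy group. Within the data shown here, only the one earlier step is known for this change, and it rose by a number 20.3 percentage points higher from compound 1 to compound 3 (beyond the scatter). A smaller step is expected here because compound 2 already stands at 96.6% and the read-out cannot rise much further. The step expected from compound 2 to compound 4 is therefore estimated at a number 4.6 percentage points lower from compound 2 to compound 4 (within the scatter). Compound 4 is expected to give about 92% in this assay, estimated between 76% and 100%.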

Compound 4, a percentage reported as activity, at one concentration (the size of the read-out at that concentration, not a potency): 52.4%
Estimate against measurement, compound 4: 39.6 percentage points above, outside the stated range (below it).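

Replacing a methoxy with hydrogen gave a number 44.2 percentage points lower from compound 2 to compound 4 (beyond the scatter) in this assay. Set beside the earlier step, this shows that the change cannot simply be carried from one core to another in this series, as even the direction of the step differs: the same change on two cores in this assay, a number 20.3 percentage points higher (beyond the scatter) from compound 1 to compound 3 and a number 44.2 percentage points lower (beyond the scatter) from compound 2 to compound 4, 64.5 percentage points apart, beyond the scatter of two such steps. It does not show which feature of the cores decides the outcome, as the two pairs differ from each other in more than one place, and two pairs tested at a single concentration give no rule for predicting the step on a third core.

The compounds shown leave open what an amine or a fluorine atom would do in place of the methoxy on either core, and whether the same contrast would hold for an ester with a longer chain than the ethyl ester of compound 2 and compound 4. Also open, from the compounds shown here alone, is the part played by the end of the side chain, which a pair of compounds alike in every other place, one a carboxylic acid and the other an ethyl ester, could help to separate from the effect of the second methoxy group.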